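The source may hold more compounds than are shown below. What is called first, only, known or untested is meant among the compounds shown, and "the series" means these compounds.

Measured so far in a functional assay on MCF7 cells (Homo sapiens) for cytotoxicity, read by MTT assay, with a stated time of 48 h; on this read-out higher numbers stand for weaker inhibition of growth and lower numbers for stronger inhibition of growth:
compound 1 (`Cn1c(C(F)(F)F)nc2cc(Cl)c(Cl)cc21`): 39000 nM
compound 2 (`FC(F)(F)c1ccc(Cn2c(C(F)(F)F)nc3cc(Cl)c(Cl)cc32)cc1`): 17000 nM

Of these two numbers, compound 1 holds the highest, and compound 2 lies lower by more than the usual scatter. Compound 3 (`Nc1cccc(Cn2c(C(F)(F)F)nc3cc(Cl)c(Cl)cc32)c1`) has not yet been measured. It departs from compound 1 by a single change (3-aminophenyl in place of hydrogen on a saturated chain carbon bound to an aromatic nitrogen): 3-aminophenyl in place of hydrogen on a saturated chain carbon bound to an aromatic nitrogen. Among the compounds with values here, no step between measured compounds is available to guide this change, so the expectation has little to rest on. Compound 2 at 17000 nM is the only other reference point, and it lies on the side of stronger inhibition of growth. A step of a 2.0-fold lower number from compound 1 to compound 3 (0.29 log units; within the scatter) is therefore expected in this assay and would be small, in the direction of stronger inhibition of growth. For compound 3 the estimated value is 20000 nM with an expected range from 8000 nM to 45000 nM as its likely bounds.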

Compound 3, concentration for 50% growth inhibition: 77500 nM
Compound 3: middle estimate off by 3.9-fold (0.59 log units), on the low side; the measured number lies above the stated range.
By their numbers in this assay, from the lowest: compound 2; then compounds 1 and 3 (each within the scatter of the next).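

In this assay, within the data shown here, putting 3-aminophenyl in place of hydrogen on a saturated chain carbon bound to an aromatic nitrogen gives a 2.0-fold higher number from compound 1 to compound 3 (0.30 log units; within the scatter) and so stays within the usual scatter, making this the first single change at this position that can be read. Compound 1 and compound 3 therefore cannot be told apart on this read-out, even though the change adds 7 heavy atoms, including one six-membered aromatic ring of carbon only, to the core of compound 1. No measurement is available that would account for this outcome.

A single step at this position leaves open whether other groups in the same place, such as a carboxylic acid, a hydroxyl group or a longer chain, would also stay within the scatter of compound 1 or would move the number clearly in either direction. It also leaves open whether 3-aminophenyl would give a similar step on a core carrying something other than the groups shared by compound 1 and compound 3.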